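A few compounds are considered here, and "the series" means these few. Any claim that something is new, unique, unknown or untested is made for them only; others in the source may bear on it.

Measured so far in an ADME assay on MT4 cells (Homo sapiens) for cytotoxicity, read by MTT assay, with a stated time of 4 days; on this read-out lower numbers stand for higher toxicity in this test and higher numbers for lower toxicity in this test:

- Compound 1 `Cc1ccc(-c2c(C)c(-c3ccc4c(c3C)CCCO4)c(C(OC(C)(C)C)C(=O)O)c(C)c2NS(C)(=O)=O)cc1C` gives 24000 nM
- Compound 2 `Cc1ccc(-c2c(C)c(-c3ccc(C)c(C)c3)c(C(OC(C)(C)C)C(=O)O)c(C)c2NS(C)(=O)=O)cc1C` gives 15000 nM
- Compound 3 `CC(=O)Nc1c(C)c(C(OC(C)(C)C)C(=O)O)c(-c2ccc(C)c(C)c2)c(C)c1-c1ccc(C)c(C)c1` gives 19000 nM

Compound 2, at 15000 nM, lies within the usual scatter of both other compounds, so the three values show no order. The next compound, compound 4 `CNc1c(C)c(C(OC(C)(C)C)C(=O)O)c(-c2ccc(C)c(C)c2)c(C)c1-c1ccc(C)c(C)c1`, has methyl in place of methylsulfonyl on a nitrogen on an aromatic ring, a change from methanesulfonamido to methylamino: methyl in place of methylsulfonyl on a nitrogen on an aromatic ring. The closest measured guide is the swap of acetyl in place of methylsulfonyl on that same nitrogen, which gave a 1.3-fold higher number from compound 2 to compound 3 (0.10 log units; within the scatter). The change elsewhere on the core gave a 1.6-fold lower number from compound 1 to compound 2 (0.20 log units; within the scatter) and bears on it less directly. Among the compounds with values here, neither step moved the number beyond the scatter, although no measured compound carries a plain methyl on that nitrogen. In this assay, no shift beyond the scatter is therefore expected, and the estimated change is a 1.1-fold lower number from compound 2 to compound 4 (0.03 log units; within the scatter). The estimated value for compound 4 is 14000 nM, with an expected range of 6500 nM to 30000 nM.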

Compound 4, half-maximal cytotoxic concentration: 8800 nM
Compound 4: the middle estimate sits 1.6-fold (0.20 log units) above what was measured, within the range that was stated.
By their numbers in this assay, from the lowest: compounds 4, 2, 3 and 1 (each within the scatter of the next, the first and the last beyond it).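

In this assay the methyl in place of methylsulfonyl on the nitrogen gives a 1.7-fold lower number from compound 2 to compound 4 (0.23 log units; within the scatter) and so stays within the scatter, even though the change removes the group's two hydrogen-bond acceptors. Against the acetyl on that same nitrogen, the methyl gives a 2.2-fold lower number from compound 3 to compound 4 (0.33 log units; beyond the scatter) and passes beyond the scatter, though only modestly, making this nitrogen the first place in the series where a single change registers. No measurement available here accounts for this difference between the two steps.

As far as these compounds go, it remains open whether an ethyl or a longer chain on that nitrogen, or a plain amine, would fall with compound 4 or with compound 3. From the compounds shown here alone, it is also open whether the methyl would give a similar step on the core of compound 1.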